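Closing the chloro question on the cyclic amide series

The source may hold more compounds than are shown below. What is called first, only, known or untested is meant among the compounds shown, and "the series" means these compounds.

The read-out throughout is a functional assay on the whole organism (Central nervous system) with Mus musculus as the target; on this read-out lower numbers stand for an effect already at smaller amounts and higher numbers for an effect only at larger amounts of compound. Compound 1 `COc1ccc(C23CCC(=O)N2CCCO3)cc1` carries a methoxy group on its aromatic ring and a fused bicyclic amide core. In this assay compound 1 gives < 150 mg/kg, which is a limit of the assay and not a number. Of the two values in hand, one sits at the limit of < 150 mg/kg in this assay, at which 1 of the 2 values shown sits, so where compound 1 truly stands within that range is not resolved. Compound 2 `O=C(CCC(=O)c1ccc(Cl)c(Cl)c1)NCCCO` is an open-chain analogue with two chlorines on its aromatic ring; in this assay compound 2 gives 500 mg/kg. Going by the values given here, no single-point step links compound 1 and compound 2, so only their two values can be read side by side.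

Compound 3 `O=C1CCC2(c3ccc(Cl)cc3)OCCCN12` is not yet measured. It differs from compound 1 by chloro in place of methoxy on an aromatic carbon. Among the compounds with values here, no measured step of this kind exists in the set, so the expected shift is none beyond the usual scatter. Compound 3 is therefore expected to give about 100 mg/kg, within 40 mg/kg to 300 mg/kg. This estimate amounts to an expected step that the limit leaves unreadable from compound 1 to compound 3, with a real chance that the assay again reports only a limit.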

Compound 3, dose for half-maximal effect: 81.2 mg/kg
Compound 3: middle estimate off by 1.2-fold (0.09 log units), on the high side, and the stated range covers the measured number.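

No step can be read from compound 1 to compound 3 in this assay, because the result for compound 1 is a limit of the assay and not a number: the limit of < 150 mg/kg in this assay, at which 1 of the 3 values shown sits.

The compounds shown leave open whether chloro in place of methoxy on an aromatic carbon of the shared core shifts the result at all, and in which direction.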